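Sulfur Returns Without Sulfanyl: Expecting Compound 4

A few compounds are considered here, and "the series" means these few. Any claim that something is new, unique, unknown or untested is made for them only; others in the source may bear on it.

Compound 1 `CC(C)C[C@@H]1NC(=O)[C@H](CS)NC1=O`: 83.3%
Compound 2 `CC(C)C[C@@H]1NC(=O)[C@H](CCCCN)NC1=O`: 0%
Compound 3 `CC(C)C[C@@H]1NC(=O)[C@H](CC(N)=O)NC1=O`: 0%

In a functional assay, tested at 2.5 mM (on this read-out lower numbers stand for less inhibition and higher numbers for more inhibition at the one concentration tested (going by the name of the read-out)), compound 1 gives 83.3%, while compound 2 gives 0% and compound 3 gives 0%. Compound 3 thus stands level with compound 2, the two lowest of the three, and far under compound 1, as a number 83.3 percentage points lower from compound 1 to compound 3 (beyond the scatter) shows. Compound 4 is `CSCC[C@@H]1NC(=O)[C@H](CC(C)C)NC1=O`; the change is (methylsulfanyl)methyl in place of carbamoyl on a saturated chain carbon bound to a saturated ring carbon. Among the compounds with values here, two measured steps bear on it: a number 83.3 percentage points lower from compound 1 to compound 3 (beyond the scatter) was large, and no change at the digits printed from compound 2 to compound 3 (within the scatter) was flat. Only compound 1, bearing sulfanyl, inhibited; compound 4 brings sulfur back as (methylsulfanyl)methyl but not sulfanyl itself, so compound 4 is expected to rise only modestly: a number 15 percentage points higher from compound 3 to compound 4 (beyond the scatter). Compound 4 is estimated at 15%, between 0% and 55%.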

Compound 4, a percentage reported as inhibition, at one concentration (the size of the read-out at that concentration, not a potency): 0%
Estimate against measurement, compound 4: 15 percentage points above, and the stated range covers the measured number.
By their numbers in this assay, from the lowest: compounds 2, 3 and 4 (each within the scatter of the next); then compound 1.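

In this assay, sulfur in this side chain is not enough on its own: (methylsulfanyl)methyl in place of carbamoyl gives no change at the digits printed from compound 3 to compound 4 (within the scatter), and the comparison with the amine-bearing chain gives no change at the digits printed from compound 2 to compound 4 (within the scatter). Set against sulfanyl, the same group gives a number 83.3 percentage points lower from compound 1 to compound 4 (beyond the scatter), so among these four compounds inhibition appears only with sulfanyl. No measurement at hand explains this difference. Still open, from the compounds shown here alone, is whether hydroxymethyl in place of sulfanyl would also inhibit, and whether a longer chain ending in sulfanyl would keep the inhibition.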